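This account rests on a few compounds, and the source may have more. Where it says the series, first, only, none or still open, it means among the compounds named here.

Measured compounds:
- Compound 1, `CN1C(=S)[C@@H](NC(=O)c2nc(Cc3ccccc3)n(CCCC(F)(F)F)n2)COc2ccccc21`: 2380 nM
- Compound 2, `CN1C(=S)[C@@H](NC(=O)c2nc(Cc3ccccc3)n(C3CCCCC3)n2)COc2ccccc21`: 4000 nM

In a functional assay on HT-29 cells (Homo sapiens) for inhibition, read by luminescence and CellTiter-Glo, with a stated time of 24 h (on this read-out higher numbers stand for an effect only at larger amounts of compound and lower numbers for an effect already at smaller amounts), compound 2 stands at the highest of the two numbers, and its nearest neighbour is compound 1. Going by the values given here, the only step measured so far, a 1.7-fold higher number from compound 1 to compound 2 (0.23 log units; within the scatter), changes the group on the same aromatic nitrogen that is changed again here, so it is the one step that bears on the move to compound 3, `CN1C(=S)[C@@H](NC(=O)c2nc(Cc3ccccc3)n(Cc3ccccc3)n2)COc2ccccc21`.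

The change from compound 2 to compound 3 is benzyl in place of cyclohexyl on an aromatic nitrogen.

Because a 1.7-fold higher number from compound 1 to compound 2 (0.23 log units; within the scatter) stayed within the scatter, the group on this aromatic nitrogen has not yet shown a clear effect on the read-out, and a step in this assay of a size beyond the scatter is not expected in either direction for compound 3; the step from compound 2 to compound 3 is estimated as a 1.1-fold lower number from compound 2 to compound 3 (0.06 log units; within the scatter). Among the compounds with values here, with only one within-scatter step behind it, this expectation rests on little, and the range is kept wide. For compound 3 the estimate in this assay is 3500 nM, with a range from 1200 nM to 10000 nM.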

Compound 3, half-maximal effective concentration: 414 nM
Beside the measured number, compound 3's estimate is 8.5-fold (0.93 log units) above it; the measured number lies below the stated range.
By their numbers in this assay, from the lowest: compound 3; then compounds 1 and 2 (each within the scatter of the next).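

In this assay, the group on this aromatic nitrogen now clearly matters: benzyl in place of cyclohexyl gives a 9.7-fold lower number from compound 2 to compound 3 (0.99 log units; beyond the scatter), and phenyl in place of 3,3,3-trifluoropropyl on the saturated chain carbon bound to that nitrogen gives a 5.7-fold lower number from compound 1 to compound 3 (0.76 log units; beyond the scatter). Both steps lie beyond the scatter, whereas the earlier step, a 1.7-fold higher number from compound 1 to compound 2 (0.23 log units; within the scatter), did not, so cyclohexyl and 4,4,4-trifluorobutyl could not be told apart, while benzyl stands apart from both. Compound 3 therefore has the lowest number of the three, but this rests on a single benzyl compound, and no accompanying measurement explains the drop.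

Whether the benzyl group's aromatic ring alone accounts for this remains open, and a phenyl group or a 2-phenylethyl chain on the same nitrogen, or a benzyl group carrying a methoxy group or a chlorine atom, would help to test it. On these data alone, the ring atom that bears a benzyl group is the same in all three compounds, so its contribution to the read-out also remains unknown.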